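Moving the Methyl Group on a Chemokine Receptor Ligand

This account rests on a few compounds, and the source may have more. Where it says the series, first, only, none or still open, it means among the compounds named here.

Three compounds have been measured in an assay on THP-1 cells for displacement of a labelled ligand from C-C chemokine receptor type 1 (Homo sapiens); on this read-out lower numbers stand for stronger inhibition and higher numbers for weaker inhibition:

Compound 1, `Cc1ccc(CCC(=O)N[C@@H](C(=O)N2CCC(c3ccc(Cl)cc3)CC2)C(C)C)cc1`, gives 105 nM.
Compound 2, `Cc1ccc(C(=O)N[C@@H](C(=O)N2CCC(c3ccc(Cl)cc3)CC2)C(C)C)cc1`, gives 25 nM.
Compound 3, `CC(C)C(NC(=O)Oc1ccccc1)C(=O)N1CCC(c2ccc(Cl)cc2)CC1`, gives 265 nM.

Compound 1 stands second highest of the three numbers: compound 3 sits higher, and compound 2, which carries 4-methylphenyl directly on the carbonyl carbon instead of the longer 2-(4-methylphenyl)ethyl, sits lower, with a 4.2-fold lower number from compound 1 to compound 2 (0.62 log units; beyond the scatter).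

Compound 4, `Cc1ccccc1CCC(=O)N[C@@H](C(=O)N1CCC(c2ccc(Cl)cc2)CC1)C(C)C`, has the same atoms as compound 1 joined differently: 2-methylphenyl in place of 4-methylphenyl on a saturated chain carbon, two bonds along the chain from a carbonyl carbon. The chain between the aromatic ring and the carbonyl carbon is unchanged; only the place of the methyl group on the ring moves.

Within the data shown here, none of the measured steps bears on this change. Among the measured compounds shown here, the only step in this assay alters the length of the chain, not the position of the methyl group, so it gives no guide here. With nothing to point in either direction, the expectation is a step within the usual scatter, that is no change at the digits printed from compound 1 to compound 4 (within the scatter), and compound 4 is estimated at 105 nM, with a range from 40 nM to 280 nM.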

Compound 4, half-maximal inhibitory concentration: 19 nM
Estimate against measurement, compound 4: 5.5-fold (0.74 log units) above; the measured number lies below the stated range.
By their numbers in this assay, from the lowest: compounds 4 and 2 (each within the scatter of the next); then compound 1; then compound 3.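

Moving the methyl group from 4-methylphenyl to 2-methylphenyl on an unchanged chain gives a 5.5-fold lower number from compound 1 to compound 4 (0.74 log units; beyond the scatter) in this assay, so the place of this single methyl group on the ring matters, even though the atoms stay the same. The earlier chain step alone could be read as favouring a ring attached directly to the carbonyl carbon, but the longer chain carrying 2-methylphenyl gives a 1.3-fold lower number from compound 2 to compound 4 (0.12 log units; within the scatter) and so cannot be told apart from that shorter arrangement, which means that the longer chain does not by itself bring a higher number. Nothing available explains why the methyl position has an effect of this size.

From the compounds shown here alone, it remains open whether the methyl group itself is needed, which a plain phenyl on the same chain would test, or whether an ethyl or methoxy group could take its place on the ring. Also open, going by these compounds, is how 2-methylphenyl behaves when attached directly to the carbonyl carbon, as the ring is in compound 2, or at the end of a longer chain.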